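Chain extension on a silent triaryl acid

This account rests on a few compounds, and the source may have more. Where it says the series, first, only, none or still open, it means among the compounds named here.

Measured so far in a functional assay for inhibition, with Homo sapiens as the target (on this read-out lower numbers stand for stronger inhibition and higher numbers for weaker inhibition), all three values being limits:
- compound 1 `O=C(O)CCCCCn1nc(-c2ccccc2)c(-c2ccccc2)c1-c1ccccc1`: > 78000 nM
- compound 2 `CCc1c(-c2ccccc2)nn(CCCCCCCCC(=O)O)c1-c1ccccc1`: > 79000 nM
- compound 3 `O=C(O)CCCCCCCCCn1cc(-c2ccccc2)c(-c2ccccc2)n1`: > 81000 nM

Compound 1 stands at a limit of this assay, > 78000 nM, and so has no true number. Compounds 2 and 3 likewise offer only limits. Compound 4 `O=C(O)CSCCCCCCn1nc(-c2ccccc2)c(-c2ccccc2)c1-c1ccccc1` has ((carboxymethyl)sulfanyl)methyl in place of carboxy on a saturated chain carbon, five bonds along the chain from an aromatic nitrogen. Going by the values given here, no measured step shows what such a change does. A modest gain in inhibition is expected, though it may not go beyond the scatter, and compound 4 may also end at a limit. The estimated step is an at least 2.2-fold lower number from compound 1 to compound 4 (0.34 log units; beyond the scatter). For compound 4 the expected value is 35000 nM, with an estimated range of 5000 nM to 80000 nM.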

Compound 4, half-maximal inhibitory concentration: 870 nM
The estimate for compound 4 lay 40-fold (1.60 log units) above the measured number; measured number below the stated range.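

In this assay, putting ((carboxymethyl)sulfanyl)methyl in place of carboxy on a saturated chain carbon, five bonds along the chain from an aromatic nitrogen, gives an at least 89-fold lower number from compound 1 to compound 4 (1.95 log units; beyond the scatter). A change at the acid end of the chain alone is thus enough to bring a measurable value to this core. As far as these compounds go, the full size of the step stays unknown because compound 1 gives only a limit: the limit of > 78000 nM in this assay, at which 1 of the 4 values shown sits. Still open, from the compounds shown here alone, is whether the sulfur or the added chain length matters: an all-carbon longer chain ending in a carboxylic acid would separate the two.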